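This account rests on a few compounds, and the source may have more. Where it says the series, first, only, none or still open, it means among the compounds named here.

For the measured compounds named here, compound 2 `COC(=O)CCNC(=O)Cn1cc(C2=C(c3c[nH]c4ccccc34)C(=O)N(C)C2=O)c2ccccc21` is one of two compounds measured in a functional assay on BGC-823 cells (Homo sapiens) for cytotoxicity, read by MTT assay, with a stated time of 24 h; a higher number here means a weaker inhibitor, a lower number a stronger inhibitor. There compound 2 gives 44900 nM, while compound 1 `COC(=O)[C@@H](C)NC(=O)Cn1cc(C2=C(c3c[nH]c4ccccc34)C(=O)N(C)C2=O)c2ccccc21` gives 60400 nM; the step of a 1.3-fold lower number from compound 1 to compound 2 (0.13 log units; within the scatter) lies within the scatter, so compound 2 stands together with compound 1 rather than apart from it. Compound 3 `COC(=O)[C@H](NC(=O)Cn1cc(C2=C(c3c[nH]c4ccccc34)C(=O)N(C)C2=O)c2ccccc21)C(C)C` is the next member of the series and has not yet been tested. It differs from compound 2 by 1-(methoxycarbonyl)-2-methylpropyl in place of 2-(methoxycarbonyl)ethyl on an amide-type nitrogen. Going by the values given here, only one measured step bears on this change, the move from compound 1 to compound 2 along the same amide-type nitrogen, and it was within the scatter. A branched ester-bearing group returning to the one-carbon spacing of compound 1 is therefore expected to leave the number much where it is, with the estimated step being a 1.1-fold higher number from compound 2 to compound 3 (0.05 log units; within the scatter). Compound 3 is thus estimated to give 50000 nM in this assay, within a range of 20000 nM to 125000 nM.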

Compound 3, half-maximal inhibitory concentration: 48200 nM
Beside the measured number, compound 3's estimate is 1.0-fold (0.02 log units) above it, within the range that was stated.
By their numbers in this assay, from the lowest: compounds 2, 3 and 1 (each within the scatter of the next).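

In this assay the exchange of groups on the amide-type nitrogen gives a 1.1-fold higher number from compound 2 to compound 3 (0.03 log units; within the scatter) and isopropyl in place of methyl on the saturated chain carbon gives a 1.3-fold lower number from compound 1 to compound 3 (0.10 log units; within the scatter). The earlier pair spoke only to moving the methoxycarbonyl group along the chain; these steps add a branched substituent on that chain, and all three compounds still lie within the scatter of one another, so neither change separates them at this position. No evidence is at hand to account for how close these numbers lie.

The compounds shown leave open whether a carboxylic acid in place of the methyl ester, or an amine on this chain, would move the number beyond the scatter. They also leave open what a longer chain carrying the ester would do.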